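Urea aryl exchange on the trimethylpiperazine analogue

The compounds below may be only part of what the source reports. "The series", "measured", "known", "first", "only" and "open" are said of these compounds alone.

compound 1 `COc1cc2c(cc1N1CCN(C)CC1)N(C(=O)Nc1cccc(Cl)c1Cl)CC2`: an assay on isolated protein for binding affinity to 5-hydroxytryptamine receptor 1D (Homo sapiens) (on this read-out lower numbers stand for stronger inhibition and higher numbers for weaker inhibition), 12.6 nM
compound 2 `COc1cc2c(cc1N1C[C@@H](C)N(C)[C@@H](C)C1)N(C(=O)Nc1cccc(Cl)c1Cl)CC2`: this assay 79.4 nM
compound 3 `COc1cc2c(cc1N1C[C@@H](C)N(C)[C@@H](C)C1)N(C(=O)c1cccc(Cl)c1)CC2`: this assay 251 nM

Compound 2 stands second highest of the three numbers: a 6.3-fold higher number from compound 1 to compound 2 (0.80 log units; beyond the scatter) separates it from compound 1, and a 3.2-fold higher number from compound 2 to compound 3 (0.50 log units; beyond the scatter) separates it from compound 3. Compound 4 `COc1cc2c(cc1N1C[C@@H](C)N(C)[C@@H](C)C1)N(C(=O)Nc1cccc(C(F)(F)F)c1F)CC2` differs from compound 2 by 2-fluoro-3-(trifluoromethyl)phenyl in place of 2,3-dichlorophenyl on an amide-type nitrogen. Neither measured step bears directly on this change. The step from compound 1 to compound 2 alters the 4-methylpiperazin-1-yl group, far from the amide-type nitrogen. The step from compound 2 to compound 3 replaces the (2,3-dichlorophenyl)amino group on the carbonyl carbon with 3-chlorophenyl, which removes the amide-type nitrogen altogether rather than exchanging one aryl for another on it. Within the data shown here, no compound in the set shows an aryl swap on that nitrogen on its own. In this assay the expected step for compound 4 is therefore a 1.3-fold higher number from compound 2 to compound 4 (0.10 log units; within the scatter), which amounts to none beyond the scatter, with wide uncertainty. Compound 4 is estimated at 100 nM, within a range from 40 nM to 250 nM.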

Compound 4, inhibition constant: 158 nM
Compound 4: the middle estimate sits 1.6-fold (0.20 log units) below what was measured; the range from low to high includes it.
By their numbers in this assay, from the lowest: compound 1; then compounds 2, 4 and 3 (each within the scatter of the next, the first and the last beyond it).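

Notes on the amide-type nitrogen: in this assay, 2-fluoro-3-(trifluoromethyl)phenyl in place of 2,3-dichlorophenyl gives a 2.0-fold higher number from compound 2 to compound 4 (0.30 log units; within the scatter), the first reading of an aryl exchange on that nitrogen with the urea kept intact. The two aryl groups are not told apart here, although the entering group has 11 heavy atoms against 8 and carries fluorine rather than chlorine, so this position accepts both within this pair. No measured information on the compounds offers an explanation for this result.

Open, going by these compounds, is whether a nitrile or a methoxy group on the aryl ring, or a pyridine ring in its place, would read differently on this nitrogen. Also open, on these data alone, is whether the same aryl exchange reads alike with 4-methylpiperazin-1-yl as the amine.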